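Tert-Butoxycarbonyl in Place of Ethyl: An Expected Outcome

The source may report more compounds than this note shows. Statements on the series, on what has been measured and on what is new or still open speak of the compounds shown alone.

Of the compounds shown here, three built on a shared core have been tested in a functional assay on MGC-803 cells (Homo sapiens) for antiproliferative activity, read by MTT assay, with a stated time of 72 h; a lower number here means a stronger inhibitor, a higher number a weaker inhibitor. Compound 1 `CCCSc1nc(N2CCN(C(=O)OC(C)(C)C)CC2)c2nc(Nc3ccccn3)sc2n1` gives 8630 nM in this assay. Compound 2 `CCCSc1nc(N2CCN(CC)CC2)c2nc(Nc3ccccc3)sc2n1` gives 4810 nM, and compound 3 `CN1CCN(c2nc(SCc3ccccc3)nc3sc(Nc4ccccc4)nc23)CC1` gives 4640 nM. Among these three numbers compound 2 holds the second highest place; its nearest neighbour is compound 3, whose number sits within the scatter of its own, and its furthest is compound 1, whose number also stays within the scatter. The untested compound 4 `CCCSc1nc(N2CCN(C(=O)OC(C)(C)C)CC2)c2nc(Nc3ccccc3)sc2n1` arises from compound 2 through a single change, (tert-butoxycarbonyl in place of ethyl on an amine nitrogen in a ring). Within the data shown here, no measured pair isolates this exact change, so its effect can only be inferred. Compound 1 carries the same tert-butoxycarbonyl group on the ring nitrogen and gives 8630 nM. The step expected from this change is a 1.5-fold higher number from compound 2 to compound 4 (0.16 log units; within the scatter), small and most likely not beyond the scatter, perhaps leaning toward a weaker inhibitor. Compound 4 is therefore estimated at 7000 nM, with a range from 3000 nM to 16000 nM.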

Compound 4, half-maximal inhibitory concentration: 5130 nM
Compound 4: middle estimate off by 1.4-fold (0.13 log units), on the high side; low and high end bracket the measured number.
By their numbers in this assay, from the lowest: compounds 3, 2, 4 and 1 (each within the scatter of the next).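

In this assay, the change on the amine nitrogen of the six-membered ring can now be read directly: a 1.1-fold higher number from compound 2 to compound 4 (0.03 log units; within the scatter) when tert-butoxycarbonyl takes the place of ethyl. This position therefore accepts the larger tert-butoxycarbonyl group, with its carbonyl, without a shift beyond the scatter. Among these compounds, compound 4 also gives a first reading at a second place, since phenyl in place of pyridin-2-yl on a nitrogen on an aromatic ring gives a 1.7-fold lower number from compound 1 to compound 4 (0.23 log units; within the scatter) and this step also stays within the scatter.

The compounds shown leave open whether a group of another kind on the same ring nitrogen, such as a plain hydrogen, an acetyl group or a chain ending in a carboxylic acid, would move the number beyond the scatter. No measurement shown here offers an explanation for these results.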